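Fluoro to hydroxy at the same aromatic carbon

This account rests on a few compounds, and the source may have more. Where it says the series, first, only, none or still open, it means among the compounds named here.

For the measured compounds named here, compound 2 `O=C(CSC(=S)N[C@H]1CCOC1=O)Nc1ccc(F)cc1` holds the only number in a functional assay on MCF7 cells (Homo sapiens) for cytotoxicity, read by MTT assay, with a stated time of 72 h (a lower number here means a stronger inhibitor, a higher number a weaker inhibitor), where compound 2 gives 5830 nM. Compound 1 `COc1ccc(NC(=O)CSC(=S)N[C@H]2CCOC2=O)cc1` reaches only a limit, > 128000 nM. Going by the values given here, the single measured step, an at least 21-fold lower number from compound 1 to compound 2 (1.34 log units; beyond the scatter), is large and sits against (the limit of > 128000 nM in this assay, at which 1 of the 2 values shown sits). Compound 3 `O=C(CSC(=S)N[C@H]1CCOC1=O)Nc1ccc(O)cc1` differs from compound 2 by hydroxy in place of fluoro on an aromatic carbon. Like the methoxy of compound 1, a hydroxy here again replaces fluoro on an aromatic carbon, so the step of an at least 21-fold lower number from compound 1 to compound 2 (1.34 log units; beyond the scatter) suggests a move back toward higher numbers, of uncertain size. Compound 3 is expected near 30000 nM, between 6000 nM and 128000 nM, a step of a 5.1-fold higher number from compound 2 to compound 3 (0.71 log units; beyond the scatter).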

Compound 3, half-maximal inhibitory concentration: > 128000 nM
Compound 3 was reported as a limit (the forecaster's own chance of this, stated with the estimate: 35%); middle value at least 4.2-fold (0.63 log units) away from the limit.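

Hydroxy in place of fluoro on this aromatic carbon gives an at least 21-fold higher number from compound 2 to compound 3 (1.34 log units; beyond the scatter), so the loss seen with methoxy is not confined to that group, and fluoro remains the only one of the three groups here with a number. Compound 3 is reported only as a limit, and the step from compound 1 to it cannot be read. Most of what is known at this position therefore rests on a single limit: the limit of > 128000 nM in this assay, at which 2 of the 3 values shown sit.

Open, on these data alone, is whether another group at this carbon, such as chloro, methyl or an amine, also gives a number, or whether fluoro stands alone. As far as these compounds go, how far compound 1 and compound 3 lie from each other also stays open.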